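Amine ring exchange at the amide: compound 3 to compound 4

A few compounds are considered here, and "the series" means these few. Any claim that something is new, unique, unknown or untested is made for them only; others in the source may bear on it.

Among the compounds with values here, compound 3 `Cc1c(C)c2c(c(C)c1O)CCC(C)(C(=O)N1CCNCC1)O2` holds the lowest of the three numbers so far in a functional assay (brain) for inhibition, with Rattus norvegicus as the target (a higher number here means a weaker inhibitor, a lower number a stronger inhibitor), where compound 3 gives 10000 nM. Compound 1 `CCNc1cccnc1N1CCN(C(=O)C2(C)CCc3c(C)c(O)c(C)c(C)c3O2)CC1` gives 12000 nM, and the step of a 1.2-fold lower number from compound 1 to compound 3 (0.08 log units; within the scatter) is within the scatter, so no order between these two is claimed. Compound 2 `Cc1c(C)c2c(c(C)c1O)CCC(C)(C(=O)N1CCN(c3ncccn3)CC1)O2` gives 23000 nM, and the step of a 2.3-fold lower number from compound 2 to compound 3 (0.36 log units; beyond the scatter) is modest. Compound 4 `Cc1c(C)c2c(c(C)c1O)CCC(C)(C(=O)N1CCCC1)O2` differs from compound 3 by pyrrolidin-1-yl in place of piperazin-1-yl on a carbonyl carbon. Within the data shown here, none of the measured steps touches this position: a 1.9-fold higher number from compound 1 to compound 2 (0.28 log units; within the scatter), a 1.2-fold lower number from compound 1 to compound 3 (0.08 log units; within the scatter) and a 2.3-fold lower number from compound 2 to compound 3 (0.36 log units; beyond the scatter) all vary the group on an amine nitrogen in a ring, and together they show only small movement, which leaves no direct guide for the step to compound 4. On that basis no step beyond the scatter is expected, and the estimated step is no change at the digits printed from compound 3 to compound 4 (within the scatter). Compound 4 is expected to give about 10000 nM in this assay, with a range from 4000 nM to 30000 nM.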

Compound 4, half-maximal inhibitory concentration: 10000 nM
For compound 4 middle estimate and measured number coincide at the digits printed; low and high end bracket the measured number.
By their numbers in this assay, from the lowest: compounds 3, 4, 1 and 2 (each within the scatter of the next, the first and the last beyond it).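

In this assay, within the data shown here, the first measured exchange on the carbonyl carbon, pyrrolidin-1-yl in place of piperazin-1-yl, gives no change at the digits printed from compound 3 to compound 4 (within the scatter). The two groups differ in ring size and in their counts of hetero atoms, hydrogen-bond donors and hydrogen-bond acceptors, yet this pair stays within the scatter, so in this one pair none of those differences shows up in the read-out. Nothing available on this series accounts for the result.

As far as these compounds go, whether this holds for other amines on the carbonyl carbon, such as piperidin-1-yl, morpholin-4-yl or an open-chain diethylamino group, remains open. From the compounds shown here alone, it is also open whether a group there, or a carboxylic acid carried on the ring nitrogen of compound 3, would move the number beyond the scatter.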